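The source may report more compounds than this note shows. Statements on the series, on what has been measured and on what is new or still open speak of the compounds shown alone.

The measured compounds and what each gives in a functional assay on OVCAR-4 cells (Homo sapiens) for antiproliferative activity, read by WST assay, with a stated time of 3 days; on this read-out lower numbers stand for stronger inhibition and higher numbers for weaker inhibition:

compound 1, `O=c1cc(I)n([C@@H]2O[C@H](CO)[C@@H](O)[C@H]2O)c(=O)[nH]1`, gives > 50000 nM, which is a limit of the assay and not a number.
compound 2, `[N-]=[N+]=Nc1cc(=O)[nH]c(=O)n1[C@@H]1O[C@H](CO)[C@@H](O)[C@H]1O`, gives > 50000 nM, also a limit.
compound 3, `O=c1[nH]c(=O)n([C@@H]2O[C@H](CO)[C@@H](O)[C@H]2O)c(I)c1F`, gives > 50000 nM, also a limit.

All three share one core, a sugar joined to a six-membered ring that carries two ring nitrogens. Compound 2 comes from compound 1 by a single change, (azido in place of iodo on an aromatic carbon), and the resulting step in this assay is a step that the two limits leave unreadable from compound 1 to compound 2. Compound 3 comes from compound 1 by a different change, (fluoro in place of hydrogen on an aromatic carbon), with the step that the two limits leave unreadable from compound 1 to compound 3. Neither step can be sized because of the limit of > 50000 nM in this assay, at which 3 of the 3 values shown sit.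

Compound 4, `[N-]=[N+]=Nc1c(F)c(=O)[nH]c(=O)n1[C@@H]1O[C@H](CO)[C@@H](O)[C@H]1O`, has not yet been measured. It differs from compound 3 by azido in place of iodo on an aromatic carbon. Within the data shown here, this is the same kind of change as the one from compound 1 to compound 2, not the same change, since in compound 3 the carbon in question is also ortho to a fluoro group (1 heavy atom), which compound 1 does not have around that place.

The step from compound 3 to compound 4 is expected to be a number no higher from compound 3 to compound 4 (the limit leaves the size open), an expectation that rests on a step that the two limits leave unreadable from compound 1 to compound 2, where the same kind of change left compound 2 at the limit, as the limit of > 50000 nM in this assay, at which 3 of the 3 values shown sit, shows. Compound 4 is therefore estimated at 50000 nM, with a likely range from 20000 nM to 100000 nM, and most probably this assay will again report only a limit.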

Compound 4, half-maximal inhibitory concentration: 1500 nM
The estimate for compound 4 lay 33-fold (1.52 log units) above the measured number; measured number below the stated range.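

In this assay, azido in place of iodo on the core that carries the fluoro group gives an at least 33-fold lower number from compound 3 to compound 4 (1.52 log units; beyond the scatter), and fluoro in place of hydrogen on the azido compound gives an at least 33-fold lower number from compound 2 to compound 4 (1.52 log units; beyond the scatter), so compound 4, the only compound shown with both groups, is also the only one that gives a number rather than a limit. The change therefore did not carry over unchanged between cores: on the core of compound 1 it left compound 2 at a limit, while on the core of compound 3 it produced a large step, so in this series its outcome depends on what else the core carries. This does not show how large either step truly is, or whether the azido group has any effect without the fluoro group, because the steps starting from a limit give only a minimum and the steps from compound 1 cannot be read: the limit of > 50000 nM in this assay, at which 3 of the 4 values shown sit.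

The compounds shown leave open whether the fluoro group could give way to a chloro or methyl group with the azido group kept in place. They also leave open whether an amine could stand in place of the azido group on the same core and still give a measurable number.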